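Working notes: cyclopropyl for bromo in a kinase series

The compounds below may be only part of what the source reports. "The series", "measured", "known", "first", "only" and "open" are said of these compounds alone.

Measured so far:
- compound 1 `Cc1c(C(=O)Nc2ccc(Oc3ncnc4[nH]cc(-c5ccccc5)c34)c(F)c2)c(=O)c2cc(Br)ccc2n1C` gives 3120 nM in an assay on isolated protein for inhibition of tyrosine-protein kinase receptor UFO (Homo sapiens), read by FRET and Z'-LYTE, with a stated time of 1.5 h; a higher number here means a weaker inhibitor, a lower number a stronger inhibitor
- compound 2 `CCCCn1c(C)c(C(=O)Nc2ccc(Oc3ncnc4[nH]cc(-c5ccccc5)c34)c(F)c2)c(=O)c2cc(C)ccc21` gives 480 nM in this assay

Compound 1 holds the higher of the two numbers. Compound 2 sits well below it, a gap beyond the usual scatter, but the two compounds differ in more than one place, so no single change can be read from that pair.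

Compound 3 `Cc1c(C(=O)Nc2ccc(Oc3ncnc4[nH]cc(-c5ccccc5)c34)c(F)c2)c(=O)c2cc(C3CC3)ccc2n1C` differs from compound 1 in one place only: cyclopropyl in place of bromo on an aromatic carbon. Within the data shown here, no measured pair isolates this change, so the expectation rests on the single anchor of compound 1. The step from compound 1 to compound 3 in this assay is expected to be small, leaning if anything toward a lower number, and most plausibly within the scatter. The expected step is a 1.6-fold lower number from compound 1 to compound 3 (0.19 log units; within the scatter). Compound 3 is estimated at 2000 nM, with a range from 600 nM to 6500 nM.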

Compound 3, half-maximal inhibitory concentration: 230 nM
Compound 3: the middle estimate sits 8.7-fold (0.94 log units) above what was measured, outside the stated range (below it).
By their numbers in this assay, from the lowest: compound 3; then compound 2; then compound 1.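

In this assay, among these compounds, cyclopropyl in place of bromo on an aromatic carbon gives a 14-fold lower number from compound 1 to compound 3 (1.13 log units; beyond the scatter), the first step that isolates a single change. The position, meta to a fused ring and para to a fused ring, is therefore not indifferent to its group: the number moves beyond the scatter although neither group carries a hydrogen-bond donor, a hydrogen-bond acceptor or a net charge. The data give no measured basis for explaining this step.

The compounds shown leave open how an amine, a carboxylic acid or a longer carbon chain would read at this position. They also leave open whether cyclopropyl gives a step of similar size on the core of compound 2.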